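Propyl on a Sulfur: What to Expect for Compound 4

The source may report more compounds than this note shows. Statements on the series, on what has been measured and on what is new or still open speak of the compounds shown alone.

The measured compounds, in a functional assay on T-24 cells (Homo sapiens) for antiproliferative activity, read by crystal violet staining, with a stated time of 96 h; a lower number here means that less compound is needed, a higher number that more compound is needed for the effect:
compound 1 `O[C@@H]1[C@@H](O)[C@H](Oc2cccc3cccc(S)c23)OC[C@H]1O` gives 45 uM
compound 2 `O[C@@H]1[C@@H](O)[C@H](Oc2ccc3cc(S)ccc3c2)OC[C@H]1O` gives 135 uM
compound 3 `CCCSc1cccc2cccc(O[C@@H]3OC[C@@H](O)[C@H](O)[C@H]3O)c12` gives 155 uM

Compound 1 and compound 2 are built from the same atoms joined differently; the difference between the two cores is not broken down here. In this assay compound 1 gives the lower number of the two, and compound 2 and compound 3 give numbers that lie within the usual scatter of each other, so nothing separates them.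

The one change that has already been measured is the move from compound 1 to compound 3: propyl in place of hydrogen on a sulfur It made a 3.4-fold higher number from compound 1 to compound 3 (0.54 log units; beyond the scatter), a modest step, and it is the only example of its kind among these compounds.

Compound 4 `CCCSc1ccc2cc(O[C@@H]3OC[C@@H](O)[C@H](O)[C@H]3O)ccc2c1` has not yet been measured. It differs from compound 2 in exactly the same way: propyl in place of hydrogen on a sulfur The surroundings of the place are described in identical words in both pairs, so this is the same change, now made on the core of compound 2 rather than the core of compound 1.

The expectation for compound 4 rests on a single earlier step, so it is held loosely. Compound 4 is expected to show a 3.0-fold higher number from compound 2 to compound 4 (0.47 log units; beyond the scatter) in this assay, because the same change gave a 3.4-fold higher number from compound 1 to compound 3 (0.54 log units; beyond the scatter). Compound 4 is therefore estimated at 400 uM, with the likely range from 150 uM to 1100 uM.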

Compound 4, concentration for half-maximal effect: 40 uM
For compound 4 the middle estimate is 10-fold (1.00 log units) above the measured one, outside the stated range (below it).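

In this assay, putting propyl in place of hydrogen on a sulfur gave a 3.4-fold lower number from compound 2 to compound 4 (0.53 log units; beyond the scatter), so on the core of compound 2 the change lowered the number rather than raising it. Set beside the earlier step, the same change moved the number in opposite directions on the two cores, by a gap too large to dismiss as ordinary assay variation: the same change on two cores in this assay, a 3.4-fold higher number (0.54 log units; beyond the scatter) from compound 1 to compound 3 and a 3.4-fold lower number (0.53 log units; beyond the scatter) from compound 2 to compound 4, 12-fold (1.07 log units) apart, beyond the scatter of two such steps. Among the compounds shown here, this shows that, for these two pairs, the result of the change could not be carried from one core to the other, but it does not show why the cores differ, and with only two pairs it gives no rule for any other core.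

The compounds shown leave open how other groups on the same sulfur would behave on each core, such as methyl, a longer chain like hexyl, or a chain carrying an amine or a carboxylic acid. They also leave open whether the opposite directions seen with propyl would persist with those groups, or whether the two cores would respond alike to some of them.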